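This account rests on a few compounds, and the source may have more. Where it says the series, first, only, none or still open, it means among the compounds named here.

Compound 1 `CNC(=O)c1cc(Oc2ccc(/C=C/C(=O)c3ccc(C)cc3)cc2)ccn1`: "not determined" (no result reported)
Compound 2 `CNC(=O)c1cc(Oc2ccc(C(=O)/C=C/c3cccc(Br)c3)cc2)ccn1`: 9940 nM

In a functional assay on A549 cells (Homo sapiens) for cytotoxicity, read by MTT assay, with a stated time of 72 h (on this read-out lower numbers stand for stronger inhibition and higher numbers for weaker inhibition), compound 2 gives 9940 nM. Within the data shown here, this is the only number in hand, since compound 1 carries "not determined" (no result reported) in this assay. Compound 3 `CNC(=O)c1cc(Oc2ccc(C(=O)/C=C/c3ccc(OC)cc3)cc2)ccn1` differs from compound 2 by 4-methoxyphenyl in place of 3-bromophenyl on a double-bonded chain carbon bound to a double-bonded chain carbon. No step between measured compounds is available, so the weight of this change cannot be read from other pairs; the expectation is a step in this assay not beyond the usual scatter, in either direction. Compound 3 is expected to give about 12000 nM, within a range of 4000 nM to 40000 nM. This estimate means a 1.2-fold higher number from compound 2 to compound 3 (0.08 log units; within the scatter).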

Compound 3, half-maximal inhibitory concentration: > 50000 nM
Compound 3 was reported as a limit; the forecaster's own chance of this, stated with the estimate: 15%; middle value at least 4.1-fold (0.61 log units) from the limit.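

In this assay, the position on a double-bonded chain carbon bound to a double-bonded chain carbon proves sensitive to this exchange: 4-methoxyphenyl in place of 3-bromophenyl gives an at least 5.0-fold higher number from compound 2 to compound 3 (0.70 log units; beyond the scatter). The value of compound 3 is a limit, so the step has a floor but no known full size: the limit of > 50000 nM in this assay, at which 1 of the 3 values shown sits.

The step exchanges 3-bromophenyl and 4-methoxyphenyl as whole groups, and the compounds shown cannot separate the substituent from its ring position. On these data alone, how 4-bromophenyl, 3-methoxyphenyl or plain phenyl would read at this position stays open.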